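The source may report more compounds than this note shows. Statements on the series, on what has been measured and on what is new or still open speak of the compounds shown alone.

Three compounds share one core and differ only in the aromatic group attached to it: compound 1 `COc1ccc(/C=C/c2cc(OC)c(OC)c(OC)c2-c2ccc(OC)cc2)cc1`, compound 2 `COc1ccc(/C=C/c2cc(OC)c(OC)c(OC)c2-c2ccccc2)cc1` and compound 3 `COc1ccc(/C=C/c2cc(OC)c(OC)c(OC)c2-c2ccc3ccccc3c2)cc1`. In a functional assay on DU-145 cells (Homo sapiens) for cytotoxicity, read by MTT assay, with a stated time of 48 h (a lower number here means a stronger inhibitor, a higher number a weaker inhibitor), compound 1 gives 34000 nM, compound 2 gives 51000 nM and compound 3 gives 32000 nM. Compound 3 does not separate from the other two, as the data show a 1.1-fold lower number from compound 1 to compound 3 (0.03 log units; within the scatter) and a 1.6-fold lower number from compound 2 to compound 3 (0.20 log units; within the scatter).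

Compound 4 `COc1ccc(/C=C/c2cc(OC)c(OC)c(OC)c2-c2ccc(OC)c(OC)c2)cc1` has not yet been measured. It keeps the shared core and changes the same position, with 3,4-dimethoxyphenyl in place of naphthalen-2-yl on an aromatic carbon.

The two steps above bear on this change, and so does a third, with hydrogen in place of methoxy: a 1.5-fold higher number from compound 1 to compound 2 (0.18 log units; within the scatter). Within the data shown here, all three swaps at this position stay within the scatter, although this rests on only three compounds. The nearest measured relative is compound 1, whose 4-methoxyphenyl group carries one methoxy group fewer than the entering group, and it gives 34000 nM.

No change beyond the scatter is therefore expected in this assay, and the direction cannot be called. The expected size is a 1.1-fold higher number from compound 3 to compound 4 (0.05 log units; within the scatter). For compound 4 the estimated value is 36000 nM, with an expected range from 18000 nM to 70000 nM.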

Compound 4, half-maximal inhibitory concentration: 34000 nM
Estimate against measurement, compound 4: 1.1-fold (0.02 log units) above, and the stated range covers the measured number.
By their numbers in this assay, from the lowest: compounds 3, 1, 4 and 2 (each within the scatter of the next).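

Among these compounds, compound 4 is the first compound in this set with two methoxy groups on the swapped ring, and in this assay the extra methoxy group leaves no visible mark (no change at the digits printed from compound 1 to compound 4 (within the scatter)). Removing both methoxy groups from this ring is also not resolved by the assay (a 1.5-fold lower number from compound 2 to compound 4 (0.18 log units; within the scatter)), and neither is replacing the two aromatic rings of naphthalen-2-yl, which have no hydrogen-bond acceptors, with 3,4-dimethoxyphenyl, which has them (a 1.1-fold higher number from compound 3 to compound 4 (0.03 log units; within the scatter)). Among these four groups, therefore, neither the methoxy groups, the second aromatic ring nor the added hydrogen-bond acceptors separate one compound from another, and no measurement at hand explains this flat result.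

Going by these compounds, all four groups are aromatic rings bearing only methoxy groups or none, so it remains open whether an amine, a carboxylic acid or a longer alkyl chain at this position would move the number beyond the scatter. The methoxy groups and the 2-(4-methoxyphenyl)ethenyl group stay fixed throughout, so it is also unknown whether this position would behave the same way if they were replaced.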